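The source may report more compounds than this note shows. Statements on the series, on what has been measured and on what is new or still open speak of the compounds shown alone.

Compound 1, `CCOC(=O)N1N=C(c2ccccc2)CC1c1cc(OC)c(OC)c(OC)c1`, gives 8920 nM in a functional assay on HT-29 cells (Homo sapiens) for antiproliferative activity, read by MTT assay, with a stated time of 48 h; on this read-out lower numbers stand for stronger inhibition of growth and higher numbers for weaker inhibition of growth.
Compound 2, `CCCOC(=O)N1N=C(c2ccccc2)CC1c1cc(OC)c(OC)c(OC)c1`, gives only a limit of the assay, > 10000 nM, in this assay.
Compound 3, `CCOC(=O)N1N=C(c2ccc(OC)cc2)CC1c1cc(OC)c(OC)c(OC)c1`, gives 6730 nM in this assay.

The step from compound 1 to compound 2 is methyl in place of hydrogen on a saturated chain carbon, two bonds along the chain from an oxygen next to a carbonyl group. In this assay it reads as an at least 1.1-fold higher number from compound 1 to compound 2 (0.04 log units; that floor lies within the scatter), a floor set because the value of compound 2 sits at the limit of > 10000 nM in this assay, at which 1 of the 3 values shown sits. The two cores differ as methoxy in place of hydrogen on an aromatic carbon, and in this assay that difference amounts to a 1.3-fold lower number from compound 1 to compound 3 (0.12 log units; within the scatter), so compound 1 and compound 3 are not told apart by this read-out.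

Compound 4, `CCCOC(=O)N1N=C(c2ccc(OC)cc2)CC1c1cc(OC)c(OC)c(OC)c1`, has not been measured in this assay. Among the measured compounds shown here, it differs from compound 3 by methyl in place of hydrogen on a saturated chain carbon, two bonds along the chain from an oxygen next to a carbonyl group, which is the same change as the one made from compound 1 to compound 2, at the same place. For the measured compounds named here, the only measured instance of that change, an at least 1.1-fold higher number from compound 1 to compound 2 (0.04 log units; that floor lies within the scatter), gives a floor that lies within the scatter and ends at a limit, so the expected step from compound 3 to compound 4 in this assay is estimated as a 1.3-fold higher number from compound 3 to compound 4 (0.13 log units; within the scatter), small and resting on that single comparison. Compound 4 is therefore expected to give about 9000 nM in this assay, with an estimated range from 5000 nM to 16000 nM, and a fair chance that only a limit is reported.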

Compound 4, concentration for 50% growth inhibition: 12700 nM
Compound 4: the middle estimate sits 1.4-fold (0.15 log units) below what was measured; the measured number falls inside the stated range.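

The new step, ethyl to propyl on the core of compound 3, is a 1.9-fold higher number from compound 3 to compound 4 (0.28 log units; within the scatter) in this assay. Set beside the same change on the core of compound 1, this reading cannot be separated from the earlier one: the same change on two cores in this assay, an at least 1.1-fold higher number (0.04 log units; that floor lies within the scatter) from compound 1 to compound 2 and a 1.9-fold higher number (0.28 log units; within the scatter) from compound 3 to compound 4; the limit leaves it open whether they differ. The result shows that on the core of compound 3 the change gives a step no larger than the usual scatter, but it does not show that the change carries over from one core to the other with the same size, and the step from compound 2 to compound 4 cannot be read either, because compound 2 gives only a limit: the limit of > 10000 nM in this assay, at which 1 of the 4 values shown sits.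

The compounds shown leave open whether a longer chain such as butyl, or a branched chain such as isopropyl, would behave like propyl in this assay, since the change is seen only as ethyl to propyl. They also leave open what an amide or a carboxylic acid in place of the ester would do, and whether a hydroxyl group or a fluorine atom in place of the methoxy group on the phenyl ring would give a number clearly apart from those seen here.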